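Working notes: bromo for chloro at compound 3, cytotoxicity

This account rests on a few compounds, and the source may have more. Where it says the series, first, only, none or still open, it means among the compounds named here.

Compound 1 `Clc1ccc(C2ON=C(c3ccccc3Cl)O2)cc1`: in an ADME assay on HEK293 cells (Homo sapiens) for cytotoxicity, read by MTT assay, with a stated time of 44 h (on this read-out higher numbers stand for weaker inhibition and lower numbers for stronger inhibition), compound 1 gives > 100000 nM, which is a limit of the assay and not a number.
Compound 2 `Cc1ccc(C2ON=C(c3ccccc3Cl)O2)cc1`: in this assay compound 2 gives > 100000 nM, again a limit.
Compound 3 `CCC1(c2cccc(Cl)c2)ON=C(c2ccccc2Cl)O1`: in this assay compound 3 gives > 100000 nM, again a limit.

Compound 3 therefore stands at the limit, and the two further values shown are limits as well. Among the measured compounds shown here, the one step among measured pairs, from compound 1 to compound 2 a step that the two limits leave unreadable from compound 1 to compound 2, is methyl in place of chloro on an aromatic carbon, and the two limits leave its size unreadable.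

Compound 4 `CCC1(c2cccc(Br)c2)ON=C(c2ccccc2Cl)O1` differs from compound 3 by bromo in place of chloro on an aromatic carbon; the place is on an aromatic carbon of a six-membered aromatic ring of carbon only, meta to a large group, and cut one bond further out the change reads 3-chlorophenyl to 3-bromophenyl. For the measured compounds named here, no measured step bears on this change. Because all three values sit at the limit of > 100000 nM in this assay, at which 3 of the 3 values shown sit, no step beyond the scatter is expected in this assay, and the step is estimated as a step that the limit leaves unreadable from compound 3 to compound 4. Compound 4 is expected to give 150000 nM in this assay, with 50000 nM to 500000 nM as its range, and a report of only a limit is thought likely.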

Compound 4, half-maximal inhibitory concentration: > 100000 nM
Compound 4: no number, only a limit; the forecaster's own chance of this, stated with the estimate: 85%; the middle value does not contradict the limit.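

No step can be read from compound 3 to compound 4, since each gives only a limit in this assay: the limit of > 100000 nM in this assay, at which 4 of the 4 values shown sit.

The compounds shown leave open what concentration, if any, would give half-maximal inhibition for any of them, so they cannot be ranked in this assay.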